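Truncating the benzyl ether of compound 1 to a methyl

The source may report more compounds than this note shows. Statements on the series, on what has been measured and on what is new or still open speak of the compounds shown alone.

Compound 1 `[O-][n+]1nc(NCOCc2ccc(Cl)cc2)[n+]([O-])c2ccccc21` has the lowest of the two numbers recorded in a functional assay on PC-3 cells (Homo sapiens) for cytotoxicity, read by MTT assay, with a stated time of 72 h (a lower number here means a stronger inhibitor, a higher number a weaker inhibitor), where compound 1 gives 5100 nM. Its nearest neighbour is compound 3 `[O-][n+]1nc(NCOCc2ccccc2)[n+]([O-])c2ccccc21`, which in this assay gives 11900 nM. The step of a 2.3-fold higher number from compound 1 to compound 3 (0.37 log units; beyond the scatter) is modest but beyond the scatter. Compound 2 `COc1ccc2c(c1)[n+]([O-])nc(NCOC(C)c1ccccc1)[n+]2[O-]` reached only a limit of this assay, > 100000 nM, which is one of the cases counted in the limit of > 100000 nM in this assay, at which 1 of the 3 values shown sits.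

The unmeasured compound 4 `CCOCNc1n[n+]([O-])c2ccccc2[n+]1[O-]` differs from compound 1 by methyl in place of 4-chlorophenyl on a saturated chain carbon bound to an oxygen on a saturated carbon. Among the compounds with values here, the only measured step that bears on this change is the removal of the chloro, a 2.3-fold higher number from compound 1 to compound 3 (0.37 log units; beyond the scatter), which already cost potency; compound 4 goes further, removing the whole ring that carried it, so a larger loss in this assay is expected, with a real chance that compound 4 only reaches a limit. The estimate for compound 4 is 40000 nM, between 12000 nM and 150000 nM, a step of a 7.8-fold higher number from compound 1 to compound 4 (0.89 log units; beyond the scatter).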

Compound 4, half-maximal inhibitory concentration: 7400 nM
Estimate against measurement, compound 4: 5.4-fold (0.73 log units) above; measured number below the stated range.
By their numbers in this assay, from the lowest: compounds 1, 4 and 3 (each within the scatter of the next, the first and the last beyond it). At a limit, above all of these: compound 2.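

In this assay, the methyl of compound 4 does the work of the whole aromatic ring at this position: the change gives a 1.5-fold higher number from compound 1 to compound 4 (0.16 log units; within the scatter), and against the unsubstituted ring it gives a 1.6-fold lower number from compound 3 to compound 4 (0.21 log units; within the scatter). Among these three compounds, then, the 4-chlorophenyl and the phenyl are not needed on this saturated chain carbon for a number in this range, and the effect of the chloro seen earlier does not amount to a need for the ring itself. Nothing shown here bears on why the ring can be given up.

As far as these compounds go, it remains open whether a longer chain in place of the methyl would stay level with compound 4, or whether an amine or a carboxylic acid at this place would shift the number. From the compounds shown here alone, whether a hydrogen could stand here instead also remains open.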